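The source may hold more compounds than are shown below. What is called first, only, known or untested is meant among the compounds shown, and "the series" means these compounds.

Measured so far in an ADME assay on microsomes from liver (Homo sapiens) for metabolic stability, with a stated time of 10 min, tested at 0.5 uM; a higher number here means that more of the compound is left, a lower number that less of the compound is left:
compound 1 `Cn1cc(-c2ccc(C(F)F)cc2)c2cc(F)c(C(=O)NS(=O)(=O)C3CC3)cc21` gives 93%
compound 2 `CC(C)COc1ncc(-c2nn(C)c3cc(C(=O)NS(C)(=O)=O)ccc23)cc1Cl` gives 100%
compound 3 `CC(C)COc1ccc(-c2cn(C)c3cc(C(=O)NS(C)(=O)=O)c(F)cc23)cn1` gives 98%

Compound 1 holds the lowest of the three values, yet its gaps to compound 3 and to compound 2 both fall within the usual scatter, so the three compounds are not separated in this assay. Going by the values given here, no pair among them differs in a single place, so no single-change step can be read from the measured set. Compound 4 `Cn1cc(-c2ccc(C(F)(F)F)cc2)c2cc(F)c(C(=O)NS(=O)(=O)C3CC3)cc21` is not yet measured. It differs from compound 1 by fluoro in place of hydrogen on a saturated chain carbon bound to an aromatic carbon and two fluorine atoms. With all three measured values sitting near full retention and indistinguishable from one another, no step beyond the scatter is expected for this change. Compound 4 is expected to stay close to compound 1, with an estimated step of a number 2 percentage points higher from compound 1 to compound 4 (within the scatter). The estimate for compound 4 in this assay is 95%, with a range from 85% to 100%.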

Compound 4, percent of the compound remaining: 100%
Estimate against measurement, compound 4: 5 percentage points below, within the range that was stated.
By their numbers in this assay, from the lowest: compounds 1, 3, 2 and 4 (each within the scatter of the next).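

Going by these compounds alone, the pair of compound 1 and compound 4 gives the first single-place comparison: in this assay, the change from difluoromethyl to trifluoromethyl on the phenyl group gives a step within the scatter (a number 7 percentage points higher from compound 1 to compound 4 (within the scatter)). At this place, fluoro in place of hydrogen therefore does not separate the two compounds. No measured finding bears on this result.

Still open, as far as these compounds go, is whether a methoxy group or a nitrile at this place would separate from compound 1 in this assay. From the compounds shown here alone, whether the same change reads alike on another core also stays open.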